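The source may report more compounds than this note shows. Statements on the series, on what has been measured and on what is new or still open speak of the compounds shown alone.

Measured so far in an in vivo ADME assay on the whole organism (strain CD-1) for pharmacokinetics, with Mus musculus as the target; a lower number here means that more of the compound stays in the plasma, a higher number that more of the compound sits outside the plasma:
compound 1 `CCCS(=O)(=O)Nc1ccc(Cl)c(C(=O)Nc2cnc3[nH]nc(OC)c3c2)c1F` gives 0.11 L/kg
compound 2 `CCCS(=O)(=O)Nc1ccc(F)c(C(=O)Nc2cnc3[nH]ncc3c2)c1F` gives 0.68 L/kg

Compound 2 stands highest of the two numbers in this assay. Compound 1 is the only other point, and its number is lower by a gap beyond the scatter. For the measured compounds named here, the two compounds differ in more than one place, so no single step is defined between them.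

Compound 3 `CCCS(=O)(=O)Nc1ccc(Cl)c(C(=O)Nc2cnc3[nH]ncc3c2)c1F` is not yet measured in this assay. Relative to compound 2 it carries chloro in place of fluoro on an aromatic carbon. Going by the values given here, no measured pair reports this exchange on its own. The step from compound 2 to compound 3 in this assay is expected to be a 1.5-fold lower number from compound 2 to compound 3 (0.18 log units; within the scatter), within the scatter. Compound 1, which also carries chloro on that aromatic carbon but differs further in its core, gives the lower 0.11 L/kg, which points downward if the step goes anywhere. Compound 3 is estimated at 0.45 L/kg in this assay, with a range from 0.15 L/kg to 1.2 L/kg.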

Compound 3, volume of distribution: 0.17 L/kg
Estimate against measurement, compound 3: 2.6-fold (0.42 log units) above; measured number inside the range.
By their numbers in this assay, from the lowest: compounds 1 and 3 (each within the scatter of the next); then compound 2.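

In this assay, for the compounds shown here, the first clean reading at this position is chloro in place of fluoro on an aromatic carbon, ortho to a large group and para to a (propylsulfonyl)amino group, which gives a 4.0-fold lower number from compound 2 to compound 3 (0.60 log units; beyond the scatter) with the rest of the structure unchanged. The low number of compound 1 therefore no longer needs its methoxy group to account for it: hydrogen in place of methoxy on an aromatic carbon gives a 1.5-fold higher number from compound 1 to compound 3 (0.19 log units; within the scatter) and leaves compound 1 and compound 3 unseparated. No measured property is available to account for the halogen step.

The compounds shown leave open where bromo, methyl or nitrile on that aromatic carbon would fall relative to fluoro and chloro. Also open, from the compounds shown here alone, is whether the halogen step carries over to the methoxy-bearing core of compound 1, or to a chain longer than propyl on the sulfonyl group.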